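Human Liver Microsome Stability of Two Pyrimidinone Esters

The source may hold more compounds than are shown below. What is called first, only, known or untested is meant among the compounds shown, and "the series" means these compounds.

Measured compounds:
compound 1 `CCCCc1nc(C(C)C)c(CC(=O)OC)c(=O)n1Cc1ccc(-c2ccccc2-c2noc(=O)[nH]2)cc1`, 10.5%
compound 2 `CCCCc1nc(C)c(CC(=O)OCC)c(=O)n1Cc1ccc(-c2ccccc2-c2noc(=O)[nH]2)cc1`, 46.6%; 46.5% (2 entries) 

Among the measured compounds shown here, in an ADME assay on microsomes from liver (Homo sapiens) for metabolic stability, with a stated time of 30 min (on this read-out higher numbers stand for a more stable compound and lower numbers for a less stable compound), compound 1 gives 10.5%, which is the only single number recorded for it; one further entry for it carries no single number. Compound 2, `CCCCc1nc(C)c(CC(=O)OCC)c(=O)n1Cc1ccc(-c2ccccc2-c2noc(=O)[nH]2)cc1`, has two entries in this assay, (the several entries of compound 2 in this assay, 46.6%; 46.5% (2 entries)), and these agree closely with one another. For the measured compounds named here, no step between compounds differing in one place is available, so what the two values show is simply that compound 2 is recorded well above compound 1 in this assay.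

Compound 3, `CCCCc1nc(C(C)C)c(C(C)C(=O)OCC)c(=O)n1Cc1ccc(-c2ccccc2-c2noc(=O)[nH]2)cc1`, has not yet been measured in this assay. It differs from compound 1 by 1-(ethoxycarbonyl)ethyl in place of (methoxycarbonyl)methyl on an aromatic carbon. 

Going by the values given here, since no measured step bears on this change, the expected step from compound 1 to compound 3 is a modest one, a number 4.5 percentage points higher from compound 1 to compound 3 (within the scatter), within or only slightly beyond the usual scatter, and in the upward direction if any. Compound 3 is therefore estimated at 15% in this assay, within a range from 4% to 38%.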

Compound 3, percent of the compound remaining: 11%
Beside the measured number, compound 3's estimate is 4 percentage points above it; the measured number falls inside the stated range.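

Among the compounds shown here, the step gives the first direct reading at this position: in this assay, placing 1-(ethoxycarbonyl)ethyl where compound 1 carries (methoxycarbonyl)methyl gives a number 0.5 percentage points higher from compound 1 to compound 3 (within the scatter). On this read-out, the two compounds cannot be told apart, even though the entering group has seven heavy atoms against five in the group it replaces and the hydrogen-bond donor and acceptor counts stay the same. Nothing among the data shown offers an explanation for this result.

The swap alters the ester and the carbon chain that joins it to the core at once, so the compounds shown do not separate these two parts, and they leave open whether a carboxylic acid, a primary amide or a longer ester chain at this position would give a different reading. Compound 2 differs from compound 1 in more than one place, which leaves open how much of the gap between their values belongs to the methyl group that stands on its core where compound 1 has isopropyl, and how much to its ester.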